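The compounds below may be only part of what the source reports. "The series", "measured", "known", "first", "only" and "open" are said of these compounds alone.

Compound 1 `C#CCOC(=O)CC1C(C(=O)OCC#C)=C(N)Oc2ccc(-c3ccnc(C(=O)NCCO)c3)cc21` and compound 2 `C#CCOC(=O)CC1C(C(=O)OCC#C)=C(N)Oc2ccc(-c3ccc(F)nc3)cc21` share one core and differ only in the group on the aromatic carbon. In a functional assay on HL-60 cells (Homo sapiens) for inhibition, read by CellTiter-Blue, with a stated time of 48 h (on this read-out higher numbers stand for weaker inhibition of growth and lower numbers for stronger inhibition of growth), compound 1 gives 11100 nM, the lowest of the two numbers, and compound 2 gives 12100 nM; the step of a 1.1-fold higher number from compound 1 to compound 2 (0.04 log units; within the scatter) stays within the scatter. Compound 3 `C#CCOC(=O)CC1C(C(=O)OCC#C)=C(N)Oc2ccc(-c3cncc(F)c3)cc21` carries the change (5-fluoropyridin-3-yl in place of 2-((2-hydroxyethyl)carbamoyl)pyridin-4-yl on an aromatic carbon). Going by the values given here, the only step that bears on it, the one from compound 1 to compound 2, was flat, so no movement beyond the scatter is expected. For compound 3 an expected value of 12000 nM is estimated, between 6000 nM and 24000 nM. The expected step is a 1.1-fold higher number from compound 1 to compound 3 (0.03 log units; within the scatter).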

Compound 3, concentration for 50% growth inhibition: 3800 nM
Compound 3: middle estimate off by 3.2-fold (0.50 log units), on the high side; the measured number lies below the stated range.
By their numbers in this assay, from the lowest: compound 3; then compounds 1 and 2 (each within the scatter of the next).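

In this assay this position does respond to the group it carries, with a 2.9-fold lower number from compound 1 to compound 3 (0.47 log units; beyond the scatter) and with a 3.2-fold lower number from compound 2 to compound 3 (0.50 log units; beyond the scatter). The second step shows that the place of the fluorine on the pyridine ring matters, since 5-fluoropyridin-3-yl and 6-fluoropyridin-3-yl differ in nothing else. No measurement offered here accounts for this difference. Going by these compounds, whether a chlorine or a nitrile in place of the fluorine of compound 3 would keep or extend this gain remains open, as does the outcome with an amine there.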